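Liver microsome clearance: aryl swap at the trifluoromethyl-bearing ring

The source may report more compounds than this note shows. Statements on the series, on what has been measured and on what is new or still open speak of the compounds shown alone.

Measured compounds:
compound 1 `COc1ccccc1C(=O)NC(=O)Nc1ccc(-c2ccccc2)c(C(F)(F)F)c1`, 15 mL.min-1.g-1
compound 2 `COc1ccccc1C(=O)NC(=O)Nc1ccc(OCC(F)(F)F)c(C(F)(F)F)c1`, 25 mL.min-1.g-1
compound 3 `COc1ccccc1C(=O)NC(=O)Nc1ccc(N2CCCCC2)c(C(F)(F)F)c1`, 26 mL.min-1.g-1

In an in vitro ADME assay on microsomes from liver (Rattus norvegicus) for metabolic stability, with a stated time of 30 min (a higher number here means faster removal of the compound, a lower number slower removal), the three values lie within the scatter of one another: a 1.7-fold higher number from compound 1 to compound 3 (0.24 log units; within the scatter) and a 1.0-fold higher number from compound 2 to compound 3 (0.02 log units; within the scatter), and likewise a 1.7-fold higher number from compound 1 to compound 2 (0.22 log units; within the scatter). Compound 3 is therefore indistinguishable from compound 1 and compound 2 on these numbers.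

Compound 4 `COc1ccccc1C(=O)NC(=O)Nc1ccc(-c2ccccn2)c(C(F)(F)F)c1` differs from compound 3 in one place: pyridin-2-yl in place of piperidin-1-yl on an aromatic carbon. Going by the values given here, no measured step covers this exact exchange; the nearest precedent is compound 1, whose phenyl at the same place gives 15 mL.min-1.g-1, within the scatter of compound 3. The three measured steps are all within the scatter, so no change beyond the scatter is expected in this assay, perhaps a slight move toward compound 1.

For compound 4 the expected value is 20 mL.min-1.g-1, range 10 mL.min-1.g-1 to 40 mL.min-1.g-1, corresponding to a 1.3-fold lower number from compound 3 to compound 4 (0.11 log units; within the scatter).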

Compound 4, intrinsic clearance in microsomes: 15 mL.min-1.g-1
Beside the measured number, compound 4's estimate is 1.3-fold (0.12 log units) above it; the range from low to high includes it.
By their numbers in this assay, from the lowest: compounds 1, 4, 2 and 3 (each within the scatter of the next).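

Exchanging piperidin-1-yl for pyridin-2-yl at this position stays within the scatter in this assay (a 1.7-fold lower number from compound 3 to compound 4 (0.24 log units; within the scatter)). The same holds against 2,2,2-trifluoroethoxy (a 1.7-fold lower number from compound 2 to compound 4 (0.22 log units; within the scatter)) and phenyl (no change at the digits printed from compound 1 to compound 4 (within the scatter)), so these four groups on this aromatic carbon cannot be told apart in this assay, whether the six-membered ring is aromatic or not and whether or not it holds a hetero atom. No evidence is available that bears on this result.

On these data alone, whether a carboxylic acid or a primary amine at this position would give a step beyond the scatter remains open. So does the effect of replacing the trifluoromethyl group.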